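From (furan-2-yl)carbonyl to (thiophen-2-yl)sulfonyl on compound 3

The source may report more compounds than this note shows. Statements on the series, on what has been measured and on what is new or still open speak of the compounds shown alone.

Three compounds have been measured in a functional assay on SiHa cells (Homo sapiens) for cytotoxicity, read by MTT assay, with a stated time of 48 h; a lower number here means a stronger inhibitor, a higher number a weaker inhibitor:

Compound 1 `CCCCCCCCNC(=O)[C@@H](NC(=O)c1ccco1)[C@@H](C)O`: 124000 nM
Compound 2 `CCCCCCCCCCCCNC(=O)[C@@H](NC(=O)c1ccco1)[C@@H](C)O`: 64300 nM
Compound 3 `CCCCCCCCCCCCCCCCCCNC(=O)[C@@H](NC(=O)c1ccco1)[C@@H](C)O`: 13400 nM

Compound 3 holds the lowest number of the three. The chain steps show it: a 9.3-fold lower number from compound 1 to compound 3 (0.97 log units; beyond the scatter) and a 4.8-fold lower number from compound 2 to compound 3 (0.68 log units; beyond the scatter), whereas a 1.9-fold lower number from compound 1 to compound 2 (0.29 log units; within the scatter).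

Compound 4 `CCCCCCCCCCCCCCCCCCNC(=O)[C@@H](NS(=O)(=O)c1cccs1)[C@@H](C)O` differs from compound 3 by (thiophen-2-yl)sulfonyl in place of (furan-2-yl)carbonyl on an amine nitrogen. None of the three measured steps bears on this change; every one of them varies only the chain on the other amide-type nitrogen, so nothing measured tells how the change on the amine nitrogen will read. Among the compounds with values here, with no guiding step, the expectation for compound 4 is a step of no more than the usual scatter, no change at the digits printed from compound 3 to compound 4 (within the scatter). Compound 4 is therefore estimated at 13400 nM, with a wide range from 4000 nM to 45000 nM.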

Compound 4, half-maximal inhibitory concentration: > 200000 nM
Compound 4 gave a limit, no number (the forecaster's own chance of this, stated with the estimate: 5%); at least 14-fold (1.17 log units) between middle value and limit.
By their numbers in this assay, from the lowest: compound 3; then compounds 2 and 1 (each within the scatter of the next). At a limit, above all of these: compound 4.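

Putting (thiophen-2-yl)sulfonyl in place of (furan-2-yl)carbonyl on the amine nitrogen gives an at least 14-fold higher number from compound 3 to compound 4 (1.17 log units; beyond the scatter), so this position, which the chain steps left unvaried, also moves the read-out well beyond the scatter. In this assay compound 4 gives > 200000 nM, which is a limit of the assay and not a number. It is the only compound at that limit: the limit of > 200000 nM in this assay, at which 1 of the 4 values shown sits.

The sulfonyl link and the thiophene ring changed together, and the compounds shown do not separate them. A (thiophen-2-yl)carbonyl or (furan-2-yl)sulfonyl group on the same nitrogen would do so.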